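This account rests on a few compounds, and the source may have more. Where it says the series, first, only, none or still open, it means among the compounds named here.

Series notes. The shared core of compound 1 `CCCC(Oc1cnn(-c2cccc(C)c2)c1)c1ccc(C(=O)NCCC(=O)O)cc1` carries a 3-methylphenyl on the aromatic nitrogen. In a functional assay on cells for antagonist activity at Glucagon receptor (Homo sapiens), read by cAMP accumulation (on this read-out higher numbers stand for weaker inhibition and lower numbers for stronger inhibition), compound 1 gives only a limit of the assay, > 20900 nM. Compound 2 `CCCC(Oc1cnn(-c2ccc(OC)cc2)c1)c1ccc(C(=O)NCCC(=O)O)cc1` carries a 4-methoxyphenyl at that position. In this assay compound 2 likewise reaches only a limit, > 21300 nM. Among the compounds with values here, compound 2 thus stands at a limit, as does the one other value shown. The step that the two limits leave unreadable from compound 1 to compound 2 has no readable size because the limit of > 20900 nM in this assay, at which 1 of the 2 values shown sits, and the limit of > 21300 nM in this assay, at which 1 of the 2 values shown sits, both sit at the edge of the assay.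

Compound 3 `CCCC(Oc1cnn(-c2cccc(CC)c2)c1)c1ccc(C(=O)NCCC(=O)O)cc1` differs from compound 2 by 3-ethylphenyl in place of 4-methoxyphenyl on an aromatic nitrogen. Within the data shown here, the only measured step that bears on this position is a step that the two limits leave unreadable from compound 1 to compound 2, which gives no readable size. The 3-ethylphenyl of compound 3 resembles the 3-methylphenyl of compound 1 more than the 4-methoxyphenyl of compound 2. Compound 1 sits at its limit > 20900 nM. The step that the limit leaves unreadable from compound 2 to compound 3 is therefore expected to stay within the scatter, with no readable direction. Compound 3 is expected to return a limit again, estimated at 30000 nM with a range from 10000 nM to 100000 nM.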

Compound 3, antagonist equilibrium constant: 4530 nM
The estimate for compound 3 lay 6.6-fold (0.82 log units) above the measured number; measured number outside the range, below it.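

In this assay compound 3 is the only one of the compounds shown to give a number rather than a limit, so the aromatic nitrogen substituent does influence this read-out: 3-ethylphenyl in place of 4-methoxyphenyl gives an at least 4.7-fold lower number from compound 2 to compound 3 (0.67 log units; beyond the scatter), and methyl in place of hydrogen on a saturated chain carbon bound to an aromatic carbon gives an at least 4.6-fold lower number from compound 1 to compound 3 (0.66 log units; beyond the scatter). Compound 1 is a limit of the assay, which leaves the size of its step open-ended: the limit of > 20900 nM in this assay, at which 1 of the 3 values shown sits.

Compound 2 is also a limit of the assay, with the same consequence for its step: the limit of > 21300 nM in this assay, at which 1 of the 3 values shown sits.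

The step to compound 3 from compound 2 swaps the whole aryl group, so the compounds shown do not separate the effect of exchanging methoxy for ethyl from that of moving the substituent; 3-methoxyphenyl and 4-ethylphenyl would separate the two. From the compounds shown here alone, whether the trend from 3-methylphenyl to 3-ethylphenyl continues also stays open, and 3-propylphenyl or a longer chain in that place would address it.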